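Urea aryl swap on a CDK8 scaffold: compound 3 estimate

A few compounds are considered here, and "the series" means these few. Any claim that something is new, unique, unknown or untested is made for them only; others in the source may bear on it.

Measured so far:
compound 1 `CNc1nccc(N2CC[C@H](NC(=O)Nc3cccc(C#N)c3)C2)n1`: 3480 nM
compound 2 `CNc1nccc(N2CC[C@H](NC(=O)Nc3ccc(OC)cc3)C2)n1`: 7160 nM

In an assay on a protein complex for displacement of a labelled ligand from CDK8/Cyclin C (Homo sapiens), read by TR-FRET, with a stated time of 1 h (on this read-out lower numbers stand for stronger inhibition and higher numbers for weaker inhibition), compound 2 gives the highest of the two numbers, with compound 1 giving 3480 nM as the nearest, and the step of a 2.1-fold higher number from compound 1 to compound 2 (0.31 log units; beyond the scatter) was modest. Compound 3 `CNc1nccc(N2CC[C@H](NC(=O)Nc3ccc(C)c(Cl)c3)C2)n1` differs from compound 2 by 3-chloro-4-methylphenyl in place of 4-methoxyphenyl on an amide-type nitrogen. No measured step carries this same exchange; the only step shown concerns a different aryl group, so it speaks to this one indirectly. On that basis the step of a 1.6-fold lower number from compound 2 to compound 3 (0.20 log units; within the scatter) is expected to be small, so compound 3 is estimated at 4500 nM, within 1500 nM to 13000 nM.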

Compound 3, half-maximal inhibitory concentration: 18.4 nM
The estimate for compound 3 lay 240-fold (2.39 log units) above the measured number, and the stated range ends above it.
By their numbers in this assay, from the lowest: compound 3; then compound 1; then compound 2.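

In this assay, the aryl group on the amide-type nitrogen can move the number far more than compound 1 and compound 2 suggested, with 3-chloro-4-methylphenyl giving a 390-fold lower number from compound 2 to compound 3 (2.59 log units; beyond the scatter) in place of 4-methoxyphenyl and a 190-fold lower number from compound 1 to compound 3 (2.28 log units; beyond the scatter) in place of 3-cyanophenyl. Against 4-methoxyphenyl, this large step comes with the heavy-atom count unchanged at 8. No measurement shown here accounts for the drop. The compounds shown leave open whether the chlorine alone or the methyl alone would give such a drop. They also leave open how an aryl group carrying an amine or a carboxylic acid would read.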